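The compounds below may be only part of what the source reports. "The series", "measured", "known", "first", "only" and "open" are said of these compounds alone.

Working notes on the series. In a functional assay on BT-474 cells (Homo sapiens) for inhibition, read by fluorescence, with a stated time of 72 h (a lower number here means a stronger inhibitor of growth, a higher number a weaker inhibitor of growth), compound 1 (`CC(C)=CCn1cnc2c(Nc3cccc(Cl)c3)nc(N[C@H]3CC[C@H](N)CC3)nc21`) gives 7000 nM as its reading. In this assay compound 2 (`CCCCn1cnc2c(NCc3cccc(Cl)c3)nc(N[C@H]3CC[C@H](N)CC3)nc21`) gives 4700 nM as its reading. Among the measured compounds shown here, the two numbers lie within the scatter of each other, so compound 1 sits level with the only other measured compound and the pair cannot be ranked.

Compound 3 (`N[C@H]1CC[C@H](Nc2nc(Nc3cccc(Cl)c3)c3ncn(Cc4ccccc4)c3n2)CC1`) keeps the core of compound 1 and differs in one place, as counted here: phenyl in place of 2-methylprop-1-en-1-yl on a saturated chain carbon bound to an aromatic nitrogen in sum. This is phenyl in place of 2-methylprop-1-en-1-yl on a saturated chain carbon bound to an aromatic nitrogen, which reads as 3-methylbut-2-en-1-yl to benzyl when cut one bond further out.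

For the measured compounds named here, no measured step covers this change, so the data give no direct guide to its size. In this assay, going by the values given here, no step beyond the scatter is expected in either direction, with compound 2 at 4700 nM as the only nearby reading. The estimate corresponds to a 1.4-fold lower number from compound 1 to compound 3 (0.15 log units; within the scatter) and this expected step stays within the scatter. For compound 3 the expected value is 5000 nM with an estimated range from 1800 nM to 14000 nM for a single measurement.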

Compound 3, concentration for 50% growth inhibition: 10200 nM
Estimate against measurement, compound 3: 2.0-fold (0.31 log units) below, and the stated range covers the measured number.
By their numbers in this assay, from the lowest: compounds 2, 1 and 3 (each within the scatter of the next, the first and the last beyond it).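

In this assay the series now has its first measured change in one place, a 1.5-fold higher number from compound 1 to compound 3 (0.16 log units; within the scatter), with phenyl in place of 2-methylprop-1-en-1-yl on a saturated chain carbon bound to an aromatic nitrogen. This step lies within the scatter, so at this position going from 3-methylbut-2-en-1-yl to benzyl, which removes a double bond outside aromatic rings and brings in a six-membered aromatic ring of carbon only, gives a pair that cannot be ranked. This single pair shows that the position can carry either group with no step beyond the scatter, and nothing available explains why the two readings stand level.

Going by these compounds, whether a chain ending in an amine or a carboxylic acid, or a pyridine ring in place of the phenyl, would give a step beyond the scatter at this position stays open. Also open, on these data alone, is whether the step from 3-methylbut-2-en-1-yl to benzyl would stay within the scatter if the other groups on the core of compound 1 were changed.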